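A few compounds are considered here, and "the series" means these few. Any claim that something is new, unique, unknown or untested is made for them only; others in the source may bear on it.

Measured in an assay on microsomes from liver for inhibition of sterol O-acyltransferase 1 (Rattus norvegicus); on this read-out lower numbers stand for stronger inhibition and higher numbers for weaker inhibition:

Compound 1 `CCCCCC[S+]([O-])c1cc(-c2ccccc2)c(-c2ccccc2)nn1` gives 75000 nM.
Compound 2 `CCCCCCC[S+]([O-])c1cc(-c2ccccc2)c(-c2ccccc2)nn1` gives 77000 nM.
Compound 3 `CCCCCCCC[S+]([O-])c1cc(-c2ccccc2)c(-c2ccccc2)nn1` gives 92000 nM.

Compound 3 has the highest of these three numbers, but the step of a 1.2-fold higher number from compound 1 to compound 3 (0.09 log units; within the scatter) and the step of a 1.2-fold higher number from compound 2 to compound 3 (0.08 log units; within the scatter) both lie within the scatter, so the three compounds cannot be told apart on potency.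

Compound 4 `CCCCCCCCC[S+]([O-])c1cc(-c2ccccc2)c(-c2ccccc2)nn1` differs from compound 3 by methyl in place of hydrogen on a saturated chain carbon, eight bonds along the chain from a sulfur. Two measured steps are the same kind of change, each adding one methyl at the end of the chain: the step of a 1.0-fold higher number from compound 1 to compound 2 (0.01 log units; within the scatter) and the step of a 1.2-fold higher number from compound 2 to compound 3 (0.08 log units; within the scatter). Neither reached beyond the scatter, so for this assay no step beyond the scatter is expected here either.

Compound 4 is therefore estimated at 100000 nM, with a range from 50000 nM to 200000 nM. That estimate means an expected step of a 1.1-fold higher number from compound 3 to compound 4 (0.04 log units; within the scatter).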

Compound 4, half-maximal inhibitory concentration: 87000 nM
Compound 4: middle estimate off by 1.1-fold (0.06 log units), on the high side; the range from low to high includes it.
By their numbers in this assay, from the lowest: compounds 1, 2, 4 and 3 (each within the scatter of the next).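

Methyl in place of hydrogen eight bonds along the chain from the sulfur gives a 1.1-fold lower number from compound 3 to compound 4 (0.02 log units; within the scatter) and so stays within the scatter, as the earlier single additions did. Larger additions to the same chain do no more: ethyl seven bonds along gives a 1.1-fold higher number from compound 2 to compound 4 (0.05 log units; within the scatter) and propyl six bonds along gives a 1.2-fold higher number from compound 1 to compound 4 (0.06 log units; within the scatter) with all of these again within the scatter. The same change also reads alike at two places on the chain: the same change on two cores in this assay, a 1.0-fold higher number (0.01 log units; within the scatter) from compound 1 to compound 2 and a 1.1-fold lower number (0.02 log units; within the scatter) from compound 3 to compound 4, 1.1-fold (0.04 log units) apart, within the scatter of two such steps.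

As far as these compounds go, whether a much longer chain would shift the number beyond the scatter stays open. So does the effect of an amine or a carboxylic acid on the chain.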